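The compounds below may be only part of what the source reports. "The series", "measured", "known", "first", "only" and "open" are said of these compounds alone.

Compound 1 `COc1c(N2CC[C@@H](CO)C2)c(F)cc2c(=O)c(C(=O)O)cn(Cc3ccc(-c4ccccc4)cc3)c12` was tested in an assay on isolated protein for inhibition of DNA topoisomerase 1 (Homo sapiens), with a stated time of 15 min (a higher number here means a weaker inhibitor, a lower number a stronger inhibitor), and there compound 1 gives > 200000 nM, which is a limit of the assay and not a number. Compound 1 therefore stands at the limit of > 200000 nM in this assay, at which 1 of the 3 values shown sits, with no measured potency to its name. Two other compounds were measured in this assay. Compound 2 `NC[C@@H]1CCN(c2cc3c(cc2F)c(=O)n(N)c(=O)n3Cc2ccc(-c3ccccc3)cc2)C1` gives 25900 nM in this assay. Compound 3 `NC[C@@H]1CCN(c2cc3c(cc2F)c(=O)c(C(=O)O)cn3Cc2ccc(-c3ccccc3)cc2)C1` gives 15600 nM in this assay. Among the compounds with values here, neither compound 2 nor compound 3 differs from compound 1 in a single place, so no step between them is counted; their values show only that both register a number where compound 1 registers a limit.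

Compound 4 `COc1c(NCCN)c(F)cc2c(=O)c(C(=O)O)cn(Cc3ccc(-c4ccccc4)cc3)c12` has not yet been measured. It differs from compound 1 by (2-aminoethyl)amino in place of 3-(hydroxymethyl)pyrrolidin-1-yl on an aromatic carbon. Because compound 3 gives 15600 nM with a chain that also carries an amino group, the author expects compound 4 to reach a measurable number, a step of an at least 5.0-fold lower number from compound 1 to compound 4 (0.69 log units; beyond the scatter) in this assay. Compound 4 is expected to give about 40000 nM in this assay, within a range from 10000 nM to 200000 nM, with a real chance that only a limit is reported again.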

Compound 4, half-maximal inhibitory concentration: > 200000 nM
Compound 4 ended at the assay's limit; the forecaster's own chance of this, stated with the estimate: 35%; middle value at least 5.0-fold (0.69 log units) away from the limit.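

In this assay, within the data shown here, compound 1 and compound 4 both stand at a limit and not at a number, so no step between them can be read: the limit of > 200000 nM in this assay, at which 2 of the 4 values shown sit. The compounds shown leave open whether (2-aminoethyl)amino or 3-(hydroxymethyl)pyrrolidin-1-yl gives the stronger inhibitor on the shared core.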